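Phenyl replaces dimethylaminoethenyl on the piperazine of compound 2

This account rests on a few compounds, and the source may have more. Where it says the series, first, only, none or still open, it means among the compounds named here.

Measured compounds:
compound 1, `Cn1c(-c2ccc(NC(=O)CSc3nc4ccccc4o3)cc2)nc(-c2ccccc2)c1-c1ccccc1`, 11.2 ug/mL
compound 2, `CN(C)/C=C/N1CCN(CC(=O)Nc2ccc(-c3nc(-c4ccccc4)c(-c4ccccc4)n3C)cc2)CC1`, 80 ug/mL

In a functional assay on MCF7 cells (Homo sapiens) for cytotoxicity, read by MTT assay, with a stated time of 24 h (on this read-out higher numbers stand for weaker inhibition and lower numbers for stronger inhibition), compound 1 gives 11.2 ug/mL, while compound 2 gives 80 ug/mL, the higher of the two numbers. Within the data shown here, the only step between them, a 7.1-fold higher number from compound 1 to compound 2 (0.85 log units; beyond the scatter), swaps the whole side group on the chain carbon bound to the carbonyl carbon. Compound 3, `Cn1c(-c2ccc(NC(=O)CN3CCN(c4ccccc4)CC3)cc2)nc(-c2ccccc2)c1-c1ccccc1`, keeps the piperazine of compound 2 and differs from it only in phenyl in place of 2-(dimethylamino)ethenyl on an amine nitrogen in a ring. Among the measured compounds shown here, no measured step touches that part alone; the step from compound 1 to compound 2 exchanges a different group and so bears only loosely on this change. Compound 3 is therefore expected to stay in the region of compound 2, and the estimate is a step of a 1.8-fold lower number from compound 2 to compound 3 (0.25 log units; within the scatter), leaning towards a somewhat lower number, because compound 1 with its aromatic side group gave 11.2 ug/mL. Compound 3 is estimated at 45 ug/mL, with a range from 15 ug/mL to 120 ug/mL.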

Compound 3, half-maximal inhibitory concentration: 10.7 ug/mL
For compound 3 the middle estimate is 4.2-fold (0.62 log units) above the measured one; measured number below the stated range.
By their numbers in this assay, from the lowest: compounds 3 and 1 (each within the scatter of the next); then compound 2.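

In this assay, the group on the amine nitrogen in the ring decides much of the outcome by itself: phenyl in place of 2-(dimethylamino)ethenyl gives a 7.5-fold lower number from compound 2 to compound 3 (0.87 log units; beyond the scatter), so keeping the piperazine does not tie a compound to the high number of compound 2. The 4-phenylpiperazin-1-yl group and the (1,3-benzoxazol-2-yl)sulfanyl group on the saturated chain carbon bound to a carbonyl carbon cannot be told apart here, with a 1.0-fold lower number from compound 1 to compound 3 (0.02 log units; within the scatter), which shows that the earlier gap between compound 1 and compound 2 does not hold for every piperazine side group. Nothing available explains why phenyl and 2-(dimethylamino)ethenyl on this nitrogen read so differently.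

The compounds shown leave open whether the aromatic ring itself matters on this nitrogen, since a benzyl group, a plain methyl group or a phenyl ring bearing a chlorine or a methoxy group could separate the ring from its direct attachment. They also leave open whether the second ring nitrogen is needed at all, a question that a morpholine or a piperidine in place of the piperazine would address.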